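Two Benzoyl Groups, One, or None

A few compounds are considered here, and "the series" means these few. Any claim that something is new, unique, unknown or untested is made for them only; others in the source may bear on it.

Measured in a functional assay on RPMI-8226 cells (Homo sapiens) for cytotoxicity, read by MTT assay, with a stated time of 48 h; on this read-out lower numbers stand for stronger inhibition and higher numbers for weaker inhibition:
- compound 1 `O=C(c1ccccc1)N(N=C1C(Cl)=C(Cl)C(Cl)=C1Cl)C(=O)c1ccccc1` gives 800 nM
- compound 2 `COC1(OC)C(Cl)=C(Cl)C(Cl)=C1Cl` gives > 5000 nM as a limit
- compound 3 `C#CC(C)(C)OC(=O)NN=C1C(Cl)=C(Cl)C(Cl)=C1Cl` gives > 5000 nM as a limit

Compound 3 stands at the limit of > 5000 nM in this assay, at which 2 of the 3 values shown sit, and so has no number of its own, only a limit. The next compound to be tested is compound 4 `O=C(NN=C1C(Cl)=C(Cl)C(Cl)=C1Cl)c1ccccc1` with the change phenyl in place of (1,1-dimethylprop-2-yn-1-yl)oxy on a carbonyl carbon in which phenyl takes the place of (1,1-dimethylprop-2-yn-1-yl)oxy on a carbonyl carbon. Phenyl on a carbonyl carbon also occurs in compound 1 with 800 nM as the only value in the series that is not a limit, and this points to stronger inhibition for the new compound. The expected change is an at least 2.0-fold lower number from compound 3 to compound 4 (0.30 log units; that floor lies within the scatter) in the direction of stronger inhibition, with its size uncertain since the starting point is only a limit. In this assay compound 4 is estimated at 2500 nM with an expected range from 700 nM to 8000 nM for the measurement.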

Compound 4, half-maximal inhibitory concentration: 600 nM
Compound 4: the middle estimate sits 4.2-fold (0.62 log units) above what was measured; measured number below the stated range.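

In this assay, phenyl in place of (1,1-dimethylprop-2-yn-1-yl)oxy on a carbonyl carbon gives an at least 8.3-fold lower number from compound 3 to compound 4 (0.92 log units; beyond the scatter). That size is only a floor, because compound 3 has a limit and no number of its own: the limit of > 5000 nM in this assay, at which 2 of the 4 values shown sit.

The second benzoyl group on the amide-type nitrogen of compound 1 also proves dispensable in this pair, since hydrogen in its place gives a 1.3-fold lower number from compound 1 to compound 4 (0.12 log units; within the scatter), so one benzoyl group and two cannot be told apart in this assay.

What remains open is how much of the gain belongs to the phenyl ring itself, as the compounds shown offer only two kinds of group on that carbonyl carbon. On these data alone, a methyl group or a pyridine ring there could settle this, and the true size of the step from compound 3 stays unknown.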